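This account rests on a few compounds, and the source may have more. Where it says the series, first, only, none or still open, it means among the compounds named here.

Series notes. Compound 1, `Cc1cc(-c2cccc(F)c2)c2ncc(CSCCc3ccccc3)n2c1`, and compound 2, `Cc1cc(I)c2ncc(CSCCc3ccccc3)n2c1`, share one core and differ only in the group on an aromatic carbon, 3-fluorophenyl in compound 1 and iodo in compound 2. In an ADME assay on HEL cells (Homo sapiens) for cytotoxicity, with a stated time of 3 days (a higher number here means that more compound is tolerated, a lower number that less compound is tolerated), compound 1 gives 20 ug/mL. For compound 2 the result in this assay is a limit of the assay, >= 4 ug/mL, and no number is known for it. The step that the limit leaves unreadable from compound 1 to compound 2 therefore has no readable size, which rests on (the limit of >= 4 ug/mL in this assay, at which 1 of the 2 values shown sits).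

Compound 3, `COc1cccc(-c2cc(C)cn3c(CSCCc4ccccc4)cnc23)c1`, is the next member, with 3-methoxyphenyl in place of iodo on an aromatic carbon. Within the data shown here, the change restores an aryl group of the kind carried by compound 1, so the closest guide is compound 1 at 20 ug/mL, while the only measured step, a step that the limit leaves unreadable from compound 1 to compound 2, offers no size to scale from. Compound 3 is expected to land near compound 1. The expected step for compound 3 is a step that the limit leaves unreadable from compound 2 to compound 3, and it cannot be tested against any measured step of readable size. The estimate for compound 3 in this assay is 20 ug/mL, expected between 7 ug/mL and 50 ug/mL.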

Compound 3, minimum cytotoxic concentration: 100 ug/mL
Estimate against measurement, compound 3: 5.0-fold (0.70 log units) below; the measured number lies above the stated range.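

This position now has its first readable step in this assay: with the aryl group kept and methoxy in place of fluoro on an aromatic carbon, the change gives a 5.0-fold higher number from compound 1 to compound 3 (0.70 log units; beyond the scatter). Carrying an aryl group on this carbon therefore does not by itself fix the read-out, since the two compounds with an aryl group here, 3-fluorophenyl and 3-methoxyphenyl, stand apart by more than the usual scatter, and the small substituent on that aryl group is enough to move the tolerated concentration. The two steps that involve compound 2 cannot be read, because the result for compound 2 is only a limit: the limit of >= 4 ug/mL in this assay, at which 1 of the 3 values shown sits.

From the compounds shown here alone, how iodo compares with either aryl group in this assay therefore stays open, and two compounds with an aryl group cannot show whether the higher number belongs to methoxy alone or would extend to other substituents. An unsubstituted phenyl, or a hydroxy, an amine or a carboxylic acid on the aryl group in place of methoxy, would show whether the result follows that substituent or is particular to compound 3.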